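Working notes: terminal aryl variation, antiproliferative screen

The source may hold more compounds than are shown below. What is called first, only, known or untested is meant among the compounds shown, and "the series" means these compounds.

Measured so far:
compound 1 `COc1ccc(C(=O)/C=C/c2ccc(F)cc2)c2c1C=CC(C)(C)O2` — > 10000 nM
compound 2 `COc1ccc(C(=O)/C=C/c2ccco2)c2c1C=CC(C)(C)O2` — > 10000 nM
compound 3 `COc1ccc(C(=O)/C=C/c2ccccc2Cl)c2c1C=CC(C)(C)O2` — > 10000 nM

In a functional assay on SK-OV-3 cells (Homo sapiens) for antiproliferative activity, read by MTT assay, with a stated time of 24 h (a lower number here means a stronger inhibitor, a higher number a weaker inhibitor), compound 1 gives > 10000 nM, which is a limit of the assay and not a number. Compound 2 likewise gives > 10000 nM, a limit. Compound 3 gives > 10000 nM, again a limit. With three limits there is no measured number to place compound 1 on; it stands at the limit, as the evidence shows: the limit of > 10000 nM in this assay, at which 3 of the 3 values shown sit. The steps among the measured compounds are accordingly unreadable: a step that the two limits leave unreadable from compound 1 to compound 2, a step that the two limits leave unreadable from compound 1 to compound 3 and a step that the two limits leave unreadable from compound 2 to compound 3 give no size and no direction.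

Compound 4 `COc1ccc(C(=O)/C=C/c2ccc(O)cc2)c2c1C=CC(C)(C)O2` is the next to be measured in this assay. Its change from compound 1: hydroxy in place of fluoro on an aromatic carbon. Going by the values given here, no measured step covers this change, and the steps that exist show nothing beyond the fact that three different aryl groups all sit at the limit. There is thus no basis to expect a step beyond the scatter in either direction. For compound 4 the estimate is 15000 nM, with the range 3000 nM to 60000 nM, most likely reported as a limit. The expected step is a step that the limit leaves unreadable from compound 1 to compound 4.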

Compound 4, half-maximal inhibitory concentration: > 10000 nM
Compound 4 was reported as a limit (the forecaster's own chance of this, stated with the estimate: 80%); the middle value does not contradict the limit.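

Compound 4 sits at the same limit as compound 1, compound 2 and compound 3, so no step among these compounds can be read in this assay: the limit of > 10000 nM in this assay, at which 4 of the 4 values shown sit.

The compounds shown leave open whether any terminal group on the shared core gives a measurable value in this assay.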